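The source may report more compounds than this note shows. Statements on the series, on what has been measured and on what is new or still open speak of the compounds shown alone.

Measured so far:
Compound 1 `CCOc1cccnc1Nc1cccc(C)n1`, which in an assay on Ltk cells with metabotropic glutamate receptor 5 (Homo sapiens) as the target, read by fluorescence and calcium flux (on this read-out lower numbers stand for stronger inhibition and higher numbers for weaker inhibition), gives 40 nM.
Compound 2 `CCOc1cc(-c2ccc(C)cc2)cnc1Nc1cccc(C)n1`, which in this assay gives 513 nM.

Going by the values given here, compound 2 stands highest of the two numbers; its only neighbour is compound 1, and the single measured step, a 13-fold higher number from compound 1 to compound 2 (1.11 log units; beyond the scatter), is large and lies beyond the scatter. Compound 3 `CCOc1cc(-c2ccsn2)cnc1Nc1cccc(C)n1` has not yet been measured. It differs from compound 2 in one place: 1,2-thiazol-3-yl in place of 4-methylphenyl on an aromatic carbon. Among the compounds with values here, only one measured step bears on this position: the step from hydrogen to a six-membered aromatic ring of carbon only raised the number sharply. Within the data shown here, the change to compound 3 keeps that position occupied but exchanges the ring for a five-membered aromatic ring with two hetero atoms, and no measured pair shows what such a ring does here. Given the large rise seen for compound 2 in a 13-fold higher number from compound 1 to compound 2 (1.11 log units; beyond the scatter), a number between those of compound 1 and compound 2 is expected, closer to compound 2. The estimate for compound 3 in this assay is 250 nM, with a range from 70 nM to 900 nM, meaning an expected step of a 2.1-fold lower number from compound 2 to compound 3 (0.31 log units; beyond the scatter).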

Compound 3, half-maximal inhibitory concentration: 243 nM
Compound 3: the middle estimate sits 1.0-fold (0.01 log units) above what was measured, within the range that was stated.
By their numbers in this assay, from the lowest: compound 1; then compound 3; then compound 2.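

In this assay, the group on this aromatic carbon does not carry one fixed penalty: 1,2-thiazol-3-yl in place of 4-methylphenyl gives a 2.1-fold lower number from compound 2 to compound 3 (0.32 log units; beyond the scatter), so the identity of the ring counts as well as the presence of one. The exchange does not recover what hydrogen gave, however, since that same thiazole ring in place of hydrogen gives a 6.1-fold higher number from compound 1 to compound 3 (0.78 log units; beyond the scatter), and both ring-bearing compounds therefore stand above compound 1. The change swaps seven heavy atoms and no hydrogen-bond acceptors for five heavy atoms and two acceptors, but nothing available separates these differences or accounts for the result.

The compounds shown leave open whether any group on this carbon can match hydrogen or improve on it, for instance a methyl, a methoxy or an amine, or whether every substituent raises the number. They also leave open how much of the result for compound 2 rests on its methyl group, which a plain phenyl ring would show, and how a six-membered ring containing nitrogen, such as a pyridine, would compare.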